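Ribosyl pyrrolopyrimidine series: thiophene in place of furan

A few compounds are considered here, and "the series" means these few. Any claim that something is new, unique, unknown or untested is made for them only; others in the source may bear on it.

Measured so far in a functional assay on K562 cells (Homo sapiens), read by MTT assay, with a stated time of 72 h; a lower number here means a stronger inhibitor, a higher number a weaker inhibitor:
compound 1, `COc1ncnc2c1c(-c1ccoc1)cn2[C@@H]1O[C@H](CO)[C@@H](O)[C@H]1O`, gives 190 nM
compound 2, `COc1ncnc2c1c(-c1cccs1)cn2[C@@H]1O[C@H](CO)[C@@H](O)[C@H]1O`, gives 70 nM
compound 3, `CSc1ncnc2c1c(-c1ccoc1)cn2[C@@H]1O[C@H](CO)[C@@H](O)[C@H]1O`, gives 60 nM

Compound 3 holds the lowest number of the three in this assay; its gap to compound 2 lies within the scatter, so no order is drawn between these two, whereas compound 1 stands further off, as a 3.2-fold lower number from compound 1 to compound 3 (0.50 log units; beyond the scatter) shows. Compound 4, `CSc1ncnc2c1c(-c1cccs1)cn2[C@@H]1O[C@H](CO)[C@@H](O)[C@H]1O`, has not yet been measured in this assay. It differs from compound 3 by thiophen-2-yl in place of furan-3-yl on an aromatic carbon. The same change, (thiophen-2-yl in place of furan-3-yl on an aromatic carbon), has been made once already among the measured compounds, giving a 2.7-fold lower number from compound 1 to compound 2 (0.43 log units; beyond the scatter). The two cores on which the change is made differ by methylsulfanyl in place of methoxy on an aromatic carbon. The surroundings of the change read the same word for word in both pairs, so it is the same change. Compound 4 is therefore expected to show a 2.4-fold lower number from compound 3 to compound 4 (0.38 log units; beyond the scatter), a step of about the size of the earlier one. Among the compounds with values here, this expectation rests on compound 3 at 60 nM and on the single earlier instance, a 2.7-fold lower number from compound 1 to compound 2 (0.43 log units; beyond the scatter). Compound 4 is estimated at 25 nM in this assay, with a likely range from 10 nM to 60 nM.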

Compound 4, half-maximal inhibitory concentration: 11600 nM
The estimate for compound 4 lay 460-fold (2.67 log units) below the measured number, and the stated range ends below it.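

In this assay, two changes that each lowered the number on their own do not add up when combined: thiophen-2-yl in place of furan-3-yl gives a 190-fold higher number from compound 3 to compound 4 (2.29 log units; beyond the scatter), and methylsulfanyl in place of methoxy gives a 170-fold higher number from compound 2 to compound 4 (2.22 log units; beyond the scatter). The step seen on the core of compound 1 is therefore no guide on the core of compound 3, as even its direction reverses: the same change on two cores in this assay, a 2.7-fold lower number (0.43 log units; beyond the scatter) from compound 1 to compound 2 and a 190-fold higher number (2.29 log units; beyond the scatter) from compound 3 to compound 4, 520-fold (2.72 log units) apart, beyond the scatter of two such steps. Read through the other change, the same set of compounds gives the same picture, yet this single set shows only that the two changes do not act independently here, not why, nor whether this extends to other groups: the same change on two cores in this assay, a 3.2-fold lower number (0.50 log units; beyond the scatter) from compound 1 to compound 3 and a 170-fold higher number (2.22 log units; beyond the scatter) from compound 2 to compound 4, 520-fold (2.72 log units) apart, beyond the scatter of two such steps.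

Still open, from the compounds shown here alone, is whether the high number needs exactly thiophen-2-yl together with methylsulfanyl, or also appears with thiophen-3-yl or furan-2-yl. Equally open, going by these compounds, is how an ethylsulfanyl group or an amine in place of methylsulfanyl would behave alongside thiophen-2-yl.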